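The compounds below may be only part of what the source reports. "The series", "measured", "known", "first", "only" and "open" are said of these compounds alone.

Measured so far:
Compound 1, `C#CCNC(=O)/C=C/c1c(/C=C/c2ccc(OC)cc2)cc(OC)cc1OC`: in a functional assay on A549 cells (Homo sapiens) for inhibition, read by MTT assay, with a stated time of 48 h (on this read-out lower numbers stand for stronger inhibition and higher numbers for weaker inhibition), compound 1 gives 6930 nM.
Compound 2, `COc1ccc(/C=C/c2cc(OC)cc(OC)c2/C=C/C(=O)N2CCCC2)cc1`: in this assay compound 2 gives 6350 nM.

Compound 1 holds the highest of the two numbers in this assay, though the gap is small: a 1.1-fold lower number from compound 1 to compound 2 (0.04 log units; within the scatter). The step to compound 3, `COc1ccc(/C=C/c2cc(OC)cc(OC)c2/C=C/C(=O)N(CC(C)C)CC(C)C)cc1`, is diisobutylamino in place of propargylamino on a carbonyl carbon. For the measured compounds named here, only one measured step bears on it, the exchange on the same carbonyl carbon, a 1.1-fold lower number from compound 1 to compound 2 (0.04 log units; within the scatter), which stayed within the scatter; it gives no sign that changing the amine on the carbonyl moves the number. Going by the values given here, no measured compound carries diisobutylamino, so the expectation rests on that single step and is held loosely. The expected step is a 1.1-fold higher number from compound 1 to compound 3 (0.03 log units; within the scatter), nothing beyond the scatter, with a wide range to cover the unknown. Compound 3 is therefore estimated at 7500 nM, between 2500 nM and 22000 nM.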

Compound 3, half-maximal inhibitory concentration: 3350 nM
Compound 3: middle estimate off by 2.2-fold (0.35 log units), on the high side, within the range that was stated.
By their numbers in this assay, from the lowest: compounds 3, 2 and 1 (each within the scatter of the next, the first and the last beyond it).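

In this assay the group on this carbonyl carbon can shift the number after all: a 2.1-fold lower number from compound 1 to compound 3 (0.32 log units; beyond the scatter) is a modest step beyond the scatter, with diisobutylamino in place of propargylamino. Against pyrrolidin-1-yl the same group does not separate, since a 1.9-fold lower number from compound 2 to compound 3 (0.28 log units; within the scatter) stays within the scatter, so the shift is read only against propargylamino. No measurement shown bears on the reason for this step, and the loss of the hydrogen-bond donor and the larger heavy-atom count of diisobutylamino cannot be told apart as contributors.

Open, as far as these compounds go, is whether a smaller open-chain group such as dimethylamino, or a ring amine such as morpholin-4-yl or piperazin-1-yl, would fall with diisobutylamino on this carbonyl carbon. Also open, from the compounds shown here alone, is how a carboxylic acid at this place would compare with these amides.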